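Imine variants on a shared diaminopyrimidine-type core

The source may report more compounds than this note shows. Statements on the series, on what has been measured and on what is new or still open speak of the compounds shown alone.

Measured compounds:
- compound 1, `CCOC(=O)/C=N/c1cnc(Nc2ccc(N3CCN(C)CC3)cc2)nc1NC1CCCC1`, 15100 nM
- compound 2, `CN1CCN(c2ccc(Nc3ncc(/N=C/c4ccccc4)c(NC4CCCC4)n3)cc2)CC1`, 28600 nM
- compound 3, `CCOC(=O)/C=N/c1cnc(Nc2ccc(N3CCN(C)CC3)cc2)nc1NC(C)C`, 7590 nM

All three were tested in a functional assay on HT-29 cells (Homo sapiens) for antiproliferative activity, read by MTT assay; on this read-out higher numbers stand for weaker inhibition and lower numbers for stronger inhibition. Compound 3 gives the lowest number of the three in this assay, but its gap to compound 1 is within the scatter, as a 2.0-fold lower number from compound 1 to compound 3 (0.30 log units; within the scatter) shows; only the gap to compound 2 lies beyond it. Compound 4, `CC(C)Nc1nc(Nc2ccc(N3CCN(C)CC3)cc2)ncc1/N=C/c1ccccc1`, has not yet been measured. It differs from compound 3 by phenyl in place of ethoxycarbonyl on a carbon with a double bond to nitrogen. The same exchange has already been seen once on this series, from compound 1 to compound 2, where it gave a 1.9-fold higher number from compound 1 to compound 2 (0.28 log units; within the scatter), a shift that stays within the scatter. Within the data shown here, only that one step bears on the present change, and the step from compound 1 to compound 3 shows that the isopropyl and cyclopentyl variants behave alike. A step of similar size and direction is therefore expected for compound 4 in this assay, namely a 1.9-fold higher number from compound 3 to compound 4 (0.28 log units; within the scatter), which does not exceed the scatter. On that basis compound 4 is estimated at 14400 nM, with a plausible range from 6000 nM to 35000 nM.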

Compound 4, half-maximal inhibitory concentration: 12100 nM
Compound 4: middle estimate off by 1.2-fold (0.08 log units), on the high side; the measured number falls inside the stated range.
By their numbers in this assay, from the lowest: compounds 3, 4, 1 and 2 (each within the scatter of the next, the first and the last beyond it).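

In this assay, the exchange of ethoxycarbonyl for phenyl on a carbon with a double bond to nitrogen can now be read twice. With a 1.6-fold higher number from compound 3 to compound 4 (0.20 log units; within the scatter) as the second reading, the earlier step no longer depends on a single pair, and it reads alike with isopropyl and with cyclopentyl on the nitrogen: the same change on two cores in this assay, a 1.9-fold higher number (0.28 log units; within the scatter) from compound 1 to compound 2 and a 1.6-fold higher number (0.20 log units; within the scatter) from compound 3 to compound 4, 1.2-fold (0.07 log units) apart, within the scatter of two such steps. Among these compounds, the exchange of cyclopentyl for isopropyl on a nitrogen on an aromatic ring, read with phenyl present, gives a 2.4-fold lower number from compound 2 to compound 4 (0.37 log units; beyond the scatter) as the first step of this kind to pass beyond the scatter, though only modestly, and it matches the reading with ethoxycarbonyl present: the same change on two cores in this assay, a 2.0-fold lower number (0.30 log units; within the scatter) from compound 1 to compound 3 and a 2.4-fold lower number (0.37 log units; beyond the scatter) from compound 2 to compound 4, 1.2-fold (0.07 log units) apart, within the scatter of two such steps. Across these four compounds, each exchange therefore reads alike whichever group stands at the other place, with no compound going against this.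

As far as these compounds go, whether phenyl and ethoxycarbonyl differ at all remains open, as both steps for that exchange stay within the scatter. Nor do the compounds shown tell how a carboxylic acid or an amide in place of ethoxycarbonyl, or a longer chain such as n-butyl in place of isopropyl, would read.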